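Shortening the alkoxy chain on the shared core

The source may report more compounds than this note shows. Statements on the series, on what has been measured and on what is new or still open speak of the compounds shown alone.

Compound 1 `CCCCCCOc1ccc2c(Cl)ccnc2c1` is the chloro member of the series; in a functional assay on RKO cells (Homo sapiens) for cytotoxicity, read by MTT assay, with a stated time of 48 h (on this read-out higher numbers stand for weaker inhibition and lower numbers for stronger inhibition), compound 1 gives 2720 nM. Within the data shown here, compound 2 `CCCCCCOc1ccc2c(NCCN(C)C)ccnc2c1` carries the (2-(dimethylamino)ethyl)amino group instead; in this assay compound 2 gives 1120 nM, the lowest of the three numbers so far. Among the measured compounds shown here, the step of a 2.4-fold lower number from compound 1 to compound 2 (0.39 log units; beyond the scatter) is the only one-place comparison in hand. Compound 3 `CN(C)CCCNc1ccnc2cc(OCc3ccc(F)cc3)ccc12` differs from compound 2 in two places; in this assay compound 3 gives 1230 nM, which lies within the scatter of the number for compound 2.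

Compound 4 `C=CCOc1ccc2c(NCCN(C)C)ccnc2c1` keeps the amine of compound 2 and differs from it only at the alkoxy side: vinyl in place of pentyl on a saturated chain carbon bound to an oxygen on an aromatic ring. For the measured compounds named here, no measured step touches the alkoxy chain, so nothing in the data sizes this change; the pair of compound 2 and compound 3, with their different alkoxy groups and amine chains, shows only that their two values lie close together. The expectation is therefore a step of a 1.6-fold higher number from compound 2 to compound 4 (0.21 log units; within the scatter), within or near the scatter. In this assay compound 4 is estimated at 1800 nM, with a range from 700 nM to 4500 nM.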

Compound 4, half-maximal inhibitory concentration: 1270 nM
The estimate for compound 4 lay 1.4-fold (0.15 log units) above the measured number; measured number inside the range.
By their numbers in this assay, from the lowest: compounds 2, 3 and 4 (each within the scatter of the next); then compound 1.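

With the amine chain held fixed, the alkoxy side now has its first one-place comparison in this assay and the step reads a 1.1-fold higher number from compound 2 to compound 4 (0.05 log units; within the scatter) for allyloxy in place of hexyloxy. Over these two groups, the shorter unsaturated chain and the longer saturated one leave the number within the scatter, so the size of this step no longer has to be inferred from compound 3, which differs from compound 2 in two places. Nothing in hand accounts for how small this step is. Still open, going by these compounds, is how this place responds to groups further from these two, such as a chain ending in a carboxylic acid or an alkoxy chain longer than hexyl. Also open, on these data alone, is whether replacing the amine chain with chloro on the allyloxy compound would give a step like the one seen on the hexyloxy pair.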